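The compounds below may be only part of what the source reports. "The series", "measured", "known", "first", "only" and "open" are said of these compounds alone.

Two compounds have been measured in a functional assay on RAW264.7 cells (Mus musculus), read by Griess assay, with a stated time of 15 min (on this read-out higher numbers stand for weaker inhibition and lower numbers for stronger inhibition), so far:

Compound 1 (`C/C=C(\C)C(=O)O[C@H]1C[C@@H](C)[C@]2(O)CC[C@](C)(/C=C3/OC(=O)C(CO)=C31)O2`) gives 5700 nM
Compound 2 (`C/C=C(\C)C(=O)O[C@H]1C[C@@H](C)[C@]2(O)CC[C@](C)(/C=C3/OC(=O)C(COC(C)=O)=C31)O2`) gives 2000 nM

Compound 2 has the lower number of the two, which makes it the stronger inhibitor of this pair. Compound 3 (`C=C(C)C(=O)O[C@H]1C[C@@H](C)[C@]2(O)CC[C@](C)(/C=C3/OC(=O)C(COC(C)=O)=C31)O2`) carries 1-methylethenyl in place of 1-methylprop-1-en-1-yl on a carbonyl carbon. For the measured compounds named here, the only measured step (a 2.9-fold lower number from compound 1 to compound 2 (0.45 log units; beyond the scatter)) was modest and came from a different change, acetyl in place of hydrogen on an oxygen on a saturated carbon, so no measured step tests this swap. With no evidence for a shift in this assay in either direction, the expected step (a 1.2-fold higher number from compound 2 to compound 3 (0.06 log units; within the scatter)) is none beyond the scatter. For compound 3 the estimate is 2300 nM (expected range 1000 nM to 5500 nM).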

Compound 3, half-maximal inhibitory concentration: 6600 nM
Compound 3: the middle estimate sits 2.9-fold (0.46 log units) below what was measured; the measured number lies above the stated range.
By their numbers in this assay, from the lowest: compound 2; then compounds 1 and 3 (each within the scatter of the next).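

Replacing 1-methylprop-1-en-1-yl with 1-methylethenyl on this carbonyl carbon is not a neutral swap: in this assay it gives a 3.3-fold higher number from compound 2 to compound 3 (0.52 log units; beyond the scatter), a modest weakening of inhibition. This shows that the group on this carbonyl carbon also affects the read-out, and that the earlier acetyl change is not the only one that does. No measurement shown explains this shift.

As far as these compounds go, whether a longer chain or a phenyl group here would strengthen or weaken inhibition remains open. It is also unknown whether this swap would have the same effect with hydrogen in place of the acetyl.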